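Two fluorophenyl analogues and a nitrophenyl newcomer

The source may report more compounds than this note shows. Statements on the series, on what has been measured and on what is new or still open speak of the compounds shown alone.

Compound 1 `O=C(/C=C/c1cccc(F)c1)NCCCCNc1ccnc2cc(Cl)ccc12` in an ADME assay on HFF-1 cells (Homo sapiens) for antiproliferative activity, read by sulforhodamine B assay, with a stated time of 2 days (on this read-out higher numbers stand for weaker inhibition of growth and lower numbers for stronger inhibition of growth), gives > 100000 nM, a limit of the assay.
Compound 2 `O=C(/C=C/c1ccc(F)cc1)NCCCCNc1ccnc2cc(Cl)ccc12` in this assay gives > 100000 nM, also a limit.

Compound 2 therefore stands at the limit, and not at a measured number. Among the measured compounds shown here, the only measured step, a step that the two limits leave unreadable from compound 1 to compound 2, cannot be sized, because the limit of > 100000 nM in this assay, at which 2 of the 2 values shown sit, holds both compounds. The move to compound 3 `O=C(/C=C/c1ccccc1[N+](=O)[O-])NCCCCNc1ccnc2cc(Cl)ccc12` is described by 2-nitrophenyl in place of 4-fluorophenyl on a double-bonded chain carbon bound to a double-bonded chain carbon. For the measured compounds named here, no measured step covers a nitrophenyl group, so the single step that exists bears only loosely on this change, and it gives no readable size or direction. The expectation for compound 3 is therefore that it stays where compound 2 stands, with a step that the limit leaves unreadable from compound 2 to compound 3 that is expected to lie within the scatter. The estimated value for compound 3 in this assay is 150000 nM, with a range from 50000 nM to 500000 nM, and most likely the assay again reports only a limit.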

Compound 3, concentration for 50% growth inhibition: > 100000 nM
Compound 3: no number, only a limit; the forecaster's own chance of this, stated with the estimate: 80%; the middle value does not contradict the limit.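

No step among compound 1, compound 2 and compound 3 can be read, since all three stop at the same limit and none gives a number: the limit of > 100000 nM in this assay, at which 3 of the 3 values shown sit.

The compounds shown leave open how the 3-fluorophenyl, 4-fluorophenyl and 2-nitrophenyl groups truly compare in this assay.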